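The source may report more compounds than this note shows. Statements on the series, on what has been measured and on what is new or still open speak of the compounds shown alone.

In an ADME assay on HeLa cells (Homo sapiens) for cytotoxicity, read by crystal violet staining, with a stated time of 72 h (a higher number here means that more compound is tolerated, a lower number that less compound is tolerated), compound 1, `CCOC(=O)c1cc(CCCOc2ccc(-c3noc(C(F)(F)F)n3)cc2)on1`, gives > 100000 nM, which is a limit of the assay. Compound 2, `CCOC(=O)c1cc(CCCOc2ccc(-c3noc(C(F)(F)F)n3)cc2[N+](=O)[O-])on1`, gives > 100000 nM, again a limit. For the measured compounds named here, compound 3, `CCOC(=O)c1cc(CCCOc2ccc(-c3noc(C(F)(F)F)n3)cc2C(F)(F)F)on1`, gives 28400 nM, the only actual number in the set. Compound 4, `CCOC(=O)c1cc(CCCOc2ccc(-c3noc(C(F)(F)F)n3)cc2N)on1`, carries amino in place of trifluoromethyl on an aromatic carbon. Going by the values given here, two measured steps bear on this change, an at least 3.5-fold lower number from compound 1 to compound 3 (0.54 log units; beyond the scatter) and an at least 3.5-fold lower number from compound 2 to compound 3 (0.54 log units; beyond the scatter). Both bring in the trifluoromethyl group that the new change takes out, while a step that the two limits leave unreadable from compound 1 to compound 2 adds nothing on size. Amino itself has not been measured at this place, so a modest move back to a higher number is expected, and compound 4 may well reach (the limit of > 100000 nM in this assay, at which 2 of the 3 values shown sit). The estimate means a 2.5-fold higher number from compound 3 to compound 4 (0.39 log units; beyond the scatter). For compound 4 the expected value is 70000 nM, with an estimated range from 25000 nM to 100000 nM.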

Compound 4, half-maximal cytotoxic concentration: > 100000 nM
Compound 4 ended at the assay's limit; the forecaster's own chance of this, stated with the estimate: 50%; middle value at least 1.4-fold (0.15 log units) away from the limit.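

In this assay, putting amino in place of trifluoromethyl on the aromatic carbon ortho to a large group gives an at least 3.5-fold higher number from compound 3 to compound 4 (0.54 log units; beyond the scatter), so the lower number of compound 3 does not carry over to this change. Compound 4 gives a limit rather than a number, and it joins the compounds at that limit: the limit of > 100000 nM in this assay, at which 3 of the 4 values shown sit. Among hydrogen, nitro, amino and trifluoromethyl at this place, only the trifluoromethyl of compound 3 gives a measured number, while the steps among compound 1, compound 2 and compound 4 cannot be read.

The compounds shown leave open whether hydrogen, nitro and amino differ at all in this assay. They also leave open whether a chlorine, a methyl or a methoxy group at this place would lower the number as trifluoromethyl does.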